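Swapping the cyclic sulfonamide for methoxyphenyl on the core

The source may hold more compounds than are shown below. What is called first, only, known or untested is meant among the compounds shown, and "the series" means these compounds.

Compound 3 `Cc1n[nH]c(-c2ncc3c(N4CCCCS4(=O)=O)ccnc3c2O)n1` gives 0.6 mL.min-1.g-1 in an ADME assay on microsomes from liver (Mus musculus) for metabolic stability (on this read-out lower numbers stand for slow clearance and higher numbers for fast clearance), the lowest of the three numbers in hand. Compound 1 `CNc1ccnc2c(O)c(-c3nc(C)n[nH]3)ncc12` gives 3.1 mL.min-1.g-1, and compound 2 `Cc1n[nH]c(-c2ncc3c(N(C)C)ccnc3c2O)n1` gives 14 mL.min-1.g-1; the steps of a 5.2-fold lower number from compound 1 to compound 3 (0.71 log units; beyond the scatter) and a 23-fold lower number from compound 2 to compound 3 (1.37 log units; beyond the scatter) set compound 3 clearly apart from both. Compound 4 `COc1ccccc1-c1ccnc2c(O)c(-c3nc(C)n[nH]3)ncc12` differs from compound 3 in one place: a group of 8 heavy atoms (7 carbon, 1 oxygen; one six-membered aromatic ring of carbon only) in place of a group of 8 heavy atoms (4 carbon, 1 nitrogen, 2 oxygen, 1 sulfur; one six-membered non-aromatic ring with 2 hetero atoms), on an aromatic carbon. Within the data shown here, no measured step exchanges a non-aromatic ring for an aromatic one, so the measured steps bear only indirectly. The step of a 4.5-fold higher number from compound 1 to compound 2 (0.65 log units; beyond the scatter) shows the read-out moving beyond the scatter with a small change at this same aromatic carbon, and the step of a 23-fold lower number from compound 2 to compound 3 (1.37 log units; beyond the scatter) shows how far the cyclic group sits from the open-chain groups. With that group removed in favour of a carbon-only aromatic ring, compound 4 is expected to show a higher number, by a step of about a 13-fold higher number from compound 3 to compound 4 (1.12 log units; beyond the scatter). Compound 4 is estimated at 8 mL.min-1.g-1, with a range of 2 mL.min-1.g-1 to 30 mL.min-1.g-1.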

Compound 4, intrinsic clearance in microsomes: 0.8 mL.min-1.g-1
The estimate for compound 4 lay 10-fold (1.00 log units) above the measured number, outside the stated range (below it).
By their numbers in this assay, from the lowest: compounds 3 and 4 (each within the scatter of the next); then compound 1; then compound 2.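

In this assay, the step to 2-methoxyphenyl at this aromatic carbon gives a 1.3-fold higher number from compound 3 to compound 4 (0.12 log units; within the scatter) and so leaves the number in the same place, which means the low value in this series is not confined to the cyclic sulfonamide: a carbon-only aromatic ring serves equally well here. Both open-chain amino groups stand apart from 2-methoxyphenyl, with an 18-fold lower number from compound 2 to compound 4 (1.24 log units; beyond the scatter) in place of dimethylamino and a 3.9-fold lower number from compound 1 to compound 4 (0.59 log units; beyond the scatter) in place of methylamino, so the two compounds with a ring at this carbon share the low end of the four. No measurement on hand accounts for these steps.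

From the compounds shown here alone, whether the methoxy group contributes remains open, as an unsubstituted phenyl would be needed to separate it from the ring. Also open, going by these compounds, is where a piperidine or a pyridine ring at this carbon would fall.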